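Methyl for Hydrogen on the Benzoyl Group of Compound 3

This account rests on a few compounds, and the source may have more. Where it says the series, first, only, none or still open, it means among the compounds named here.

Of the compounds shown here, three sharing one core have been measured in a functional assay on PC-3 cells (Homo sapiens) for cytotoxicity, read by MTT assay, with a stated time of 48 h; on this read-out higher numbers stand for weaker inhibition and lower numbers for stronger inhibition. Compound 1 `COc1cc(-c2nnc3n2NC(c2ccco2)C(C(=O)c2ccccc2C)S3)cc(OC)c1OC` gives 88400 nM, compound 2 `COc1cc(-c2nnc3n2NC(c2ccco2)C(C(=O)c2cccs2)S3)cc(OC)c1OC` gives 46200 nM, and compound 3 `COc1cc(-c2nnc3n2NC(c2ccco2)C(C(=O)c2ccccc2)S3)cc(OC)c1OC` gives 64300 nM. Compound 3 lies within the scatter of both other measured compounds: a 1.4-fold lower number from compound 1 to compound 3 (0.14 log units; within the scatter), and a 1.4-fold higher number from compound 2 to compound 3 (0.14 log units; within the scatter). Compound 4 `COc1cc(-c2nnc3n2NC(c2ccco2)C(C(=O)c2ccc(C)cc2)S3)cc(OC)c1OC` differs from compound 3 by methyl in place of hydrogen on an aromatic carbon. The step that bears most on this is the removal of the methyl of the 2-methylphenyl group, where a 1.4-fold lower number from compound 1 to compound 3 (0.14 log units; within the scatter); exchanging the whole group on the carbonyl carbon also moved little, as a 1.9-fold lower number from compound 1 to compound 2 (0.28 log units; within the scatter). No step beyond the scatter is therefore expected. Compound 4 is estimated at 70000 nM, with a range from 30000 nM to 160000 nM. The expected step is a 1.1-fold higher number from compound 3 to compound 4 (0.04 log units; within the scatter).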

Compound 4, half-maximal inhibitory concentration: 7500 nM
Compound 4: the middle estimate sits 9.3-fold (0.97 log units) above what was measured, outside the stated range (below it).
By their numbers in this assay, from the lowest: compound 4; then compounds 2, 3 and 1 (each within the scatter of the next).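

In this assay, for the compounds shown here, a single methyl turns out to matter when it sits para to a large group: adding it there gives an 8.6-fold lower number from compound 3 to compound 4 (0.93 log units; beyond the scatter) and so moves well beyond the scatter that held all the earlier steps. Its place counts too: a 12-fold lower number from compound 1 to compound 4 (1.07 log units; beyond the scatter) comes with 4-methylphenyl in place of 2-methylphenyl, and a 6.2-fold lower number from compound 2 to compound 4 (0.79 log units; beyond the scatter) comes with 4-methylphenyl in place of thiophen-2-yl. Nothing available here explains this drop.

Going by these compounds, whether an ethyl group, a methoxy group or an amine on that same aromatic carbon would keep the number this low remains open.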